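A pyrazole replaces fluorophenyl in a low-toxicity series

The compounds below may be only part of what the source reports. "The series", "measured", "known", "first", "only" and "open" are said of these compounds alone.

- Compound 1 `Cc1cc(-c2ccc3[nH]c(=O)nc(-c4ccccc4)c3c2)ccn1`: > 50000 nM (a limit, not a number)
- Compound 2 `O=c1nc(-c2ccccc2)c2cc(-c3ccccc3F)ccc2[nH]1`: 55800 nM
- Compound 3 `CNC(=O)c1cccc(-c2ccc3[nH]c(=O)nc(-c4ccccc4)c3c2)c1`: > 50000 nM (a limit, not a number)

For the measured compounds named here, in an ADME assay on L6 cells (Rattus norvegicus) for cytotoxicity, read by fluorescence and resazurin assay, with a stated time of 72 h (on this read-out higher numbers stand for an effect only at larger amounts of compound and lower numbers for an effect already at smaller amounts), compound 2 gives 55800 nM, the only true number of the three. The other two results are limits, and they set the scene: the limit of > 50000 nM in this assay, at which 2 of the 3 values shown sit.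

The next compound, compound 4 `O=c1nc(-c2ccccc2)c2cc(-c3cn[nH]c3)ccc2[nH]1`, has not yet been measured. The change is 1H-pyrazol-4-yl in place of 2-fluorophenyl on an aromatic carbon.

Going by the values given here, the only measured step that bears on this swap of one aromatic group for another is a step that the limit leaves unreadable from compound 1 to compound 2. It offers no size to carry over. The best anchor is therefore compound 2 at 55800 nM, and no clear shift in either direction is expected in this assay.

The expected change is a 1.1-fold lower number from compound 2 to compound 4 (0.05 log units; within the scatter), with no movement beyond the usual scatter anticipated. For compound 4 the estimate is 50000 nM, with an expected range from 20000 nM to 100000 nM.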

Compound 4, half-maximal effective concentration: > 50000 nM
Compound 4: no number, only a limit; the forecaster's own chance of this, stated with the estimate: 55%; the middle value sits exactly at the limit.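

In this assay compound 4 gives > 50000 nM, a limit and not a number, so its steps from compound 1 and compound 2 cannot be read. The compounds shown leave open where compound 1, compound 3 and compound 4 truly stand relative to compound 2, the only one with a number: the limit of > 50000 nM in this assay, at which 3 of the 4 values shown sit.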